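The source may report more compounds than this note shows. Statements on the series, on what has been measured and on what is new or still open speak of the compounds shown alone.

Measured so far:
compound 1, `CCc1cccc(NC(=O)N[C@H](C)c2ccccc2)c1`, 97%
compound 2, `CC(C)c1cccc(NC(=O)N[C@H](C)c2ccccc2)c1`, 74%
compound 3, `CC(C)c1cccc(NC(=O)N[C@@H](C)c2ccccc2)c1`, 95%

In an ADME assay on the whole organism with Oryza sativa as the target, tested at 0.1 uM (on this read-out lower numbers stand for a stronger effect and higher numbers for a weaker effect at the one concentration tested), compound 2 stands lowest of the three numbers, with compound 3 nearest and compound 1 furthest. The next compound, compound 4 `CC(=O)c1cccc(NC(=O)N[C@H](C)c2ccccc2)c1`, differs from compound 2 in one place: acetyl in place of isopropyl on an aromatic carbon. Within the data shown here, one measured step touches the same side group, a number 23 percentage points lower from compound 1 to compound 2 (beyond the scatter), so altering this group has shifted the read-out by a modest amount. The other step, a number 21 percentage points higher from compound 2 to compound 3 (beyond the scatter), concerns configuration only, because of the fact that compounds 2 and 3 differ only in the configuration as drawn, and says nothing directly about this group. A modest step is therefore expected, and since compound 2 sits lowest, a rise seems more likely than a fall; the expected step is a number 11 percentage points higher from compound 2 to compound 4 (beyond the scatter). Compound 4 is estimated at 85%, within 65% to 100%.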

Compound 4, a percentage reported as activity, at one concentration (the size of the read-out at that concentration, not a potency): 98%
Compound 4: middle estimate off by 13 percentage points, on the low side; the range from low to high includes it.
By their numbers in this assay, from the lowest: compound 2; then compounds 3, 1 and 4 (each within the scatter of the next).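

Replacing isopropyl with acetyl on this aromatic carbon gives a number 24 percentage points higher from compound 2 to compound 4 (beyond the scatter), so the lower number of compound 2 does not survive this swap, even though both groups count three heavy atoms. Acetyl and ethyl cannot be told apart, with a number 1 percentage points higher from compound 1 to compound 4 (within the scatter), so of the three groups at this position only isopropyl stands apart. Nothing at hand bears on the reason for this difference. Going by these compounds, whether a tert-butyl or cyclopropyl group here would keep the lower number of compound 2 remains open. So does whether an amine would behave like acetyl.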